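Compound 3 and the step to compound 4

This account rests on a few compounds, and the source may have more. Where it says the series, first, only, none or still open, it means among the compounds named here.

Measured so far in an ADME assay on microsomes from liver (Mus musculus) for metabolic stability; a higher number here means that the compound lasts longer, a lower number that the compound disappears faster
Compound 1 `CCC(CC)(c1nnc[nH]1)c1ccc(-c2ccc3cc(F)cc(F)c3c2)[nH]c1=O` gives 1.09 h
Compound 2 `CC(C)C(Nc1nnc[nH]1)c1ccc(-c2ccc3cccc(F)c3c2)[nH]c1=O` gives 2.42 h
Compound 3 `CC(C)C(c1ccc(-c2ccc3cccc(F)c3c2)[nH]c1=O)N1CCN/C1=N\C#N` gives 0.207 h

Compound 3 stands lowest of the three in this assay, well beyond the scatter from both others. Compound 4 `CC(C)C(c1ncc[nH]1)c1ccc(-c2ccc3cccc(F)c3c2)[nH]c1=O` is not yet measured, and it differs from compound 3 at one place: a group of 5 heavy atoms (3 carbon, 2 nitrogen; one five-membered aromatic ring with 2 hetero atoms) in place of a group of 8 heavy atoms (4 carbon, 4 nitrogen; one five-membered non-aromatic ring with 2 hetero atoms), on a saturated chain carbon bound to an aromatic carbon and a saturated chain carbon. Among the measured compounds shown here, one measured step bears on this place, a 12-fold lower number from compound 2 to compound 3 (1.07 log units; beyond the scatter), which is large and came when the non-aromatic ring group entered in place of a five-membered aromatic ring. Compound 4 returns to a five-membered aromatic ring, so a large rise is expected, in the opposite direction to that step. The expected change is a 4.8-fold higher number from compound 3 to compound 4 (0.68 log units; beyond the scatter). For compound 4 the estimated half-life is 1 h, with an expected range of 0.35 h to 3 h.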

Compound 4, half-life: < 0.0667 h
Compound 4 gave a limit, no number; the forecaster's own chance of this, stated with the estimate: 5%; middle value at least 14-fold (1.17 log units) from the limit.
By their numbers in this assay, from the lowest: compound 3; then compound 1; then compound 2. At a limit, below all of these: compound 4.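

Compound 4 gives a limit and not a number in this assay: the limit of < 0.0667 h in this assay, at which 1 of the 4 values shown sits. A five-membered aromatic ring at this place, on a saturated chain carbon, therefore does not by itself go with a longer half-life: 1H-imidazol-2-yl gives an at least 3.1-fold lower number from compound 3 to compound 4 (0.49 log units; beyond the scatter) and an at least 36-fold lower number from compound 2 to compound 4 (1.55 log units; beyond the scatter). The non-aromatic ring group of compound 3 thus sits between the two aromatic groups rather than lowest.

The compounds shown leave open whether this fall follows from the ring or from the linking amine of compound 2. A (1H-imidazol-2-yl)amino group at this place would separate the two.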